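Imidazole-fused series: aryl swap at the core, antiproliferative readout

This account rests on a few compounds, and the source may have more. Where it says the series, first, only, none or still open, it means among the compounds named here.

Measured so far:
compound 1 `COc1ccc(-c2ccc3ncn(-c4cc(OC)c(OC)c(OC)c4)c3c2)cc1O` — 44 nM
compound 2 `COc1cc(-n2cnc3ccc(-c4cccc(Cl)c4)cc32)cc(OC)c1OC` — 1490 nM
compound 3 `COc1cc(-n2cnc3ccc(-c4cccc(O)c4)cc32)cc(OC)c1OC` — 53 nM

All three share one core and differ only in the aryl group attached to it; the readout is a functional assay on SGC-7901 cells (Homo sapiens) for antiproliferative activity, read by MTT assay, with a stated time of 72 h; a higher number here means a weaker inhibitor, a lower number a stronger inhibitor. Compound 1 gives the lowest number of the three, with compound 3 within the scatter of it and compound 2 far away: a 1.2-fold higher number from compound 1 to compound 3 (0.08 log units; within the scatter), a 34-fold higher number from compound 1 to compound 2 (1.53 log units; beyond the scatter).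

Compound 4 `COc1cc(-n2cnc3ccc(-c4cccc(C)c4C)cc32)cc(OC)c1OC` is not yet measured. It differs from compound 1 as follows: 2,3-dimethylphenyl in place of 3-hydroxy-4-methoxyphenyl on an aromatic carbon.

The informative precedents are the two steps that exchange an aryl bearing a hydroxy for one bearing a chloro, or back: a 34-fold higher number from compound 1 to compound 2 (1.53 log units; beyond the scatter) and a 28-fold lower number from compound 2 to compound 3 (1.45 log units; beyond the scatter). The hydroxy-for-hydrogen step, a 1.2-fold higher number from compound 1 to compound 3 (0.08 log units; within the scatter), lay within the scatter. The entering 2,3-dimethylphenyl, like the 3-chlorophenyl of compound 2, carries no hydroxy and no methoxy, so the closest analogy is the step to compound 2. Compound 4 is therefore expected to show a large upward step, a 34-fold higher number from compound 1 to compound 4 (1.53 log units; beyond the scatter), in this assay. The estimate for compound 4 is 1500 nM, with a range of 400 nM to 6000 nM. Within the data shown here, only one precedent of this kind exists, so the range is kept wide.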

Compound 4, half-maximal inhibitory concentration: 3040 nM
The estimate for compound 4 lay 2.0-fold (0.31 log units) below the measured number, within the range that was stated.
By their numbers in this assay, from the lowest: compounds 1 and 3 (each within the scatter of the next); then compound 2; then compound 4.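

In this assay, a second aryl group carrying neither hydroxy nor methoxy also lands far from the hydroxy-bearing compounds, with a 69-fold higher number from compound 1 to compound 4 (1.84 log units; beyond the scatter) and a 57-fold higher number from compound 3 to compound 4 (1.76 log units; beyond the scatter), so the high number at this position does not depend on chloro. Among the four compounds, only the aryl groups bearing a hydroxy give low numbers, and none goes against this. The two aryl groups without hydroxy are also separated from each other, with a 2.0-fold higher number from compound 2 to compound 4 (0.31 log units; beyond the scatter), so compound 4 has the highest number of the series.

Nothing available explains the gap between aryl groups with and without hydroxy. Going by these compounds, whether an amine or a carboxylic acid on this aryl ring could stand in for the hydroxy stays open, as does the separate contribution of each methyl of the 2,3-dimethylphenyl group.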